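Quinoline-linked pyrimidine nitriles: cell growth inhibition notes

The compounds below may be only part of what the source reports. "The series", "measured", "known", "first", "only" and "open" are said of these compounds alone.

Measured compounds in an ADME assay on L1210 cells (Mus musculus) for inhibition, read by cell counting; on this read-out higher numbers stand for weaker inhibition and lower numbers for stronger inhibition:
compound 1, `CSc1nc(OCCCNc2ccnc3cc(Cl)ccc23)c(C#N)c(-c2ccccc2)n1`, gives 3900 nM
compound 2, `CSc1nc(NCCCCNc2ccnc3cc(Cl)ccc23)c(C#N)c(-c2cccc([N+](=O)[O-])c2)n1`, gives 2100 nM
compound 3, `CSc1nc(-c2ccc([N+](=O)[O-])cc2)c(C#N)c(N2CCN(c3ccnc4cc(Cl)ccc34)CC2)n1`, gives 206000 nM

Compound 2 has the lowest of the three numbers. Compound 1 lies nearest, with a difference inside the usual scatter, so no order between compound 2 and compound 1 can be claimed; compound 3 lies furthest, with a gap well beyond the scatter. Among the measured compounds shown here, no two measured compounds differ in a single place, so no single measured step can be read off. Compound 4, `COc1cc(-c2nc(SC)nc(NCCCCNc3ccnc4cc(Cl)ccc34)c2C#N)cc(OC)c1OC`, is not yet measured and differs from compound 2 by 3,4,5-trimethoxyphenyl in place of 3-nitrophenyl on an aromatic carbon. For the measured compounds named here, with no measured step of this kind to lean on, the step expected in this assay is small, a 1.4-fold higher number from compound 2 to compound 4 (0.15 log units; within the scatter), and not beyond the scatter in either direction. Compound 4 is therefore estimated at 3000 nM, with a range from 700 nM to 13000 nM.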

Compound 4, half-maximal inhibitory concentration: 3800 nM
Estimate against measurement, compound 4: 1.3-fold (0.10 log units) below; measured number inside the range.
By their numbers in this assay, from the lowest: compounds 2, 4 and 1 (each within the scatter of the next); then compound 3.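

Among the compounds shown here, the first single-place step falls on the aromatic carbon ortho to a cyano group: in this assay, 3,4,5-trimethoxyphenyl in place of 3-nitrophenyl gives a 1.8-fold higher number from compound 2 to compound 4 (0.26 log units; within the scatter). This position therefore carries either substituted phenyl group with no readable change in the number, so the two substitution patterns cannot be ranked here. No measurement on hand offers an explanation for this result. On these data alone, whether an amine or a carboxylic acid on this phenyl ring would move the number beyond the scatter stays open.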